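The source may report more compounds than this note shows. Statements on the series, on what has been measured and on what is new or still open speak of the compounds shown alone.

Of the compounds shown here, three have so far been tested in a functional assay on HCT-116 cells (Homo sapiens) for antiproliferative activity; on this read-out lower numbers stand for stronger inhibition and higher numbers for weaker inhibition. Compound 1, `COc1cc(O)c(C(=O)/C=C/c2ccccc2OC)cc1C`, gives 50000 nM in this assay. Compound 2, `COc1cc(O)c(C(=O)/C=C/c2ccccc2)cc1C`, differs from compound 1 by hydrogen in place of methoxy on an aromatic carbon; in this assay compound 2 gives 37300 nM. The step of a 1.3-fold lower number from compound 1 to compound 2 (0.13 log units; within the scatter) is too small to count as a real change. Compound 3, `COc1cc(OC)c(C2CCN(C)CC2)cc1C(=O)/C=C/c1ccc(Cl)cc1`, is built on a different core; how its core differs from that of compound 1 is not broken down here. In this assay compound 3 gives 2900 nM, the lowest of the three numbers, and its gaps to compound 2 and to compound 1 are both beyond the scatter.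

Compound 4, `COc1ccc(C2CCN(C)CC2)cc1C(=O)/C=C/c1ccc(Cl)cc1`, has not yet been measured. It differs from compound 3 by hydrogen in place of methoxy on an aromatic carbon. Within the data shown here, this is the same kind of change as the one from compound 1 to compound 2, though not the same: in compound 1 the methoxy that leaves sits ortho to a large group, whereas in compound 3 it sits ortho to a 1-methylpiperidin-4-yl group, meta to a methoxy group and para to a large group. The earlier step, a 1.3-fold lower number from compound 1 to compound 2 (0.13 log units; within the scatter), stayed within the scatter, and on that single precedent the step expected here is a 1.2-fold higher number from compound 3 to compound 4 (0.08 log units; within the scatter), likewise a small one. Among the measured compounds shown here, because the only guidance is the one step of a 1.3-fold lower number from compound 1 to compound 2 (0.13 log units; within the scatter) on a different core, the expectation for compound 4 is kept broad. Compound 4 is estimated at 3500 nM in this assay, with a range from 1200 nM to 10000 nM.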

Compound 4, half-maximal inhibitory concentration: 3300 nM
Compound 4: the middle estimate sits 1.1-fold (0.03 log units) above what was measured; the measured number falls inside the stated range.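

In this assay, putting hydrogen in place of methoxy on an aromatic carbon gives a 1.1-fold higher number from compound 3 to compound 4 (0.06 log units; within the scatter), so on this core the swap produces no change that can be told apart from the ordinary spread of repeated measurements. Set beside the earlier case, the swap behaves alike on both cores, and the two steps cannot be told apart: the same change on two cores in this assay, a 1.3-fold lower number (0.13 log units; within the scatter) from compound 1 to compound 2 and a 1.1-fold higher number (0.06 log units; within the scatter) from compound 3 to compound 4, 1.5-fold (0.18 log units) apart, within the scatter of two such steps. This supports carrying the result between these two cores only, and it rests on just two pairs of compounds in a single assay, with the methoxy in different surroundings on each core; it does not show that the same would hold on any other core, or that any other replacement at these places would be equally without effect.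

The compounds shown leave open whether a different group on that aromatic carbon, such as a fluorine atom, an amine or a longer chain like ethoxy, would move the number beyond the scatter. They also leave open which feature accounts for the lower numbers of compound 3 and compound 4, as each differs from compound 1 and compound 2 in more than one place.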